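The compounds below may be only part of what the source reports. "The series", "measured", "known", "first", "only" and "open" are said of these compounds alone.

Compound 3, `Cc1c(OCCCCOc2ccc(F)c(C(=O)O)c2)ccc(C(=O)CC2CCCC2)c1O`, gives the highest of the three numbers recorded so far in an assay on HEK293 cells for positive allosteric modulation of metabotropic glutamate receptor 3 (Rattus norvegicus), read by thallium flux, with a stated time of 2.5 min (a higher number here means a larger maximal response, a lower number a smaller maximal response), where compound 3 reaches 98.4%. Its nearest neighbour is compound 2, `CCC(=O)c1ccc(OCCCCOc2ccc(F)c(C(=O)O)c2)c(C)c1O`, with 18.4%, and furthest away stands compound 1, `Cc1c(OCCCCOc2cccc(C(=O)O)c2)ccc(C(=O)CC(C)C)c1C`, with 18.3%. Both of these lie well beyond the scatter below compound 3.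

Compound 4, `COc1ccc(C(=O)O)cc1OCCCCOc1ccc(C(=O)CC2CCCC2)c(O)c1C`, is the next compound to be tested. It differs from compound 3 in one place: 5-carboxy-2-methoxyphenyl in place of 3-carboxy-4-fluorophenyl on an oxygen on a saturated carbon.

Among the measured compounds shown here, only one measured step is available, and it concerns a different part of the molecule. From compound 2 to compound 3 the largest response rose by a number 80 percentage points higher from compound 2 to compound 3 (beyond the scatter) when cyclopentyl replaced methyl on a saturated chain carbon bound to a carbonyl carbon. For the measured compounds named here, no measured pair separates the 3-carboxy-4-fluorophenyl group from the 5-carboxy-2-methoxyphenyl group, so the data give no direct guide to the change in compound 4. Because compound 3 already holds the cyclopentyl group that gave a number 80 percentage points higher from compound 2 to compound 3 (beyond the scatter), and compound 4 keeps it, the author expects most of that response to persist, with a modest downward step of a number 16.4 percentage points lower from compound 3 to compound 4 (beyond the scatter) in this assay to allow for the untested aryl change. Compound 4 is therefore estimated at 82%, within a range from 45% to 105%.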

Compound 4, largest response reached (reported as percent of maximum), in percent of the reference or control that the assay uses: 67.6%
For compound 4 the middle estimate is 14.4 percentage points above the measured one; the measured number falls inside the stated range.
By their numbers in this assay, from the lowest: compounds 1 and 2 (each within the scatter of the next); then compound 4; then compound 3.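

Among the compounds shown here, compound 4 gives the first reading of this position with the cyclopentyl group held in place: in this assay, exchanging the 3-carboxy-4-fluorophenyl group for the 5-carboxy-2-methoxyphenyl group gives a number 30.8 percentage points lower from compound 3 to compound 4 (beyond the scatter), so the aryl group here also shapes the maximal response and the cyclopentyl group alone does not fix it. For the compounds shown here, the single step combines the loss of fluorine with the gain of methoxy, so it cannot assign the fall to either one, and it remains smaller than a number 80 percentage points higher from compound 2 to compound 3 (beyond the scatter). Nothing among the available data explains why the response fell at this position.

The compounds shown leave open whether a methoxy or a fluorine in the other's place on the aryl ring would give the same response, and how a chlorine or a methyl there would compare. They also leave open whether a primary amide or a tetrazole could stand in for the carboxylic acid, and whether a longer chain between the two oxygens would preserve the response.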